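From methoxy to ethoxy on compound 2

The compounds below may be only part of what the source reports. "The series", "measured", "known", "first", "only" and "open" are said of these compounds alone.

Measured in a functional assay on HeLa cells (Homo sapiens) for antiproliferative activity, with a stated time of 48 h; on this read-out higher numbers stand for weaker inhibition and lower numbers for stronger inhibition:
- Compound 1 `C=C(Br)C(=O)Nc1ccc(/C=C/C(=O)c2ccc(Cl)cc2)cc1`: 1600 nM
- Compound 2 `C=C(Br)C(=O)Nc1ccc(/C=C/C(=O)c2ccc(OC)cc2)cc1`: 1400 nM

Compound 2 gives 1400 nM, which lies within the usual scatter of compound 1 at 1600 nM, so the two values cannot be told apart. Compound 3 `C=C(Br)C(=O)Nc1ccc(/C=C/C(=O)c2ccc(OCC)cc2)cc1` keeps the shared core and makes a single change: methyl in place of hydrogen on a saturated chain carbon bound to an oxygen on an aromatic ring. In words, this is methyl in place of hydrogen on a saturated chain carbon bound to an oxygen on an aromatic ring, or methoxy to ethoxy. For the measured compounds named here, only one measured step offers guidance: a 1.1-fold lower number from compound 1 to compound 2 (0.06 log units; within the scatter). It put methoxy in place of chloro on an aromatic carbon and stayed within the scatter. One small step is thin evidence, but it gives no reason to expect a clear change in this assay in either direction. The expected result is no change at the digits printed from compound 2 to compound 3 (within the scatter), which is no shift beyond the scatter. For compound 3 the estimated value is 1400 nM, with an expected range of 700 nM to 2800 nM.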

Compound 3, half-maximal inhibitory concentration: 750 nM
Compound 3: the middle estimate sits 1.9-fold (0.27 log units) above what was measured; the range from low to high includes it.
By their numbers in this assay, from the lowest: compounds 3, 2 and 1 (each within the scatter of the next, the first and the last beyond it).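

In this assay the added methyl gives a 1.9-fold lower number from compound 2 to compound 3 (0.27 log units; within the scatter) and so, taken alone, does not separate ethoxy from methoxy on this ring. For the compounds shown here, the comparison with chloro adds something new: ethoxy in place of chloro gives a 2.1-fold lower number from compound 1 to compound 3 (0.33 log units; beyond the scatter) and is the first single change here to pass the usual scatter, though only modestly, while methoxy in place of chloro gave a 1.1-fold lower number from compound 1 to compound 2 (0.06 log units; within the scatter) and did not. The substituent on this aromatic carbon can therefore shift the number a little, but no measurement shown here bears on why.

On these data alone, three compounds cannot establish a trend with chain length, so it remains open whether a longer chain such as propoxy would give a lower number, a higher one or much the same. An amine or a carboxylic acid at this place could also behave quite differently from the groups shown.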